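Swapping Benzyl for Aminophenyl on a Weak Inhibitor

A few compounds are considered here, and "the series" means these few. Any claim that something is new, unique, unknown or untested is made for them only; others in the source may bear on it.

Measured so far:
compound 1, `COc1ccc(Oc2ccc([N+](=O)[O-])cc2-c2ccsc2S(=O)(=O)N2CCN(C(=O)Nc3ccc([N+](=O)[O-])cc3)CC2)cc1OC`, a limit of the assay: > 50000 nM
compound 2, `O=S(=O)(c1sccc1-c1ccccc1Oc1ccc(O)c(O)c1)N1CCN(C(=S)Nc2cc(C(F)(F)F)cc(C(F)(F)F)c2)CC1`, a limit of the assay: > 20000 nM
compound 3, `O=C(NCCNS(=O)(=O)c1ccc(-c2ccccc2OCc2ccccc2)s1)Nc1cc(C(F)(F)F)cc(C(F)(F)F)c1`: 13500 nM

In a functional assay on HeLa cells (Homo sapiens) for inhibition, read by CCK-8 assay, with a stated time of 48 h (a lower number here means a stronger inhibitor, a higher number a weaker inhibitor), only compound 3 gives a number at all. For compound 1 the result is a limit, not a measured value. For compound 2 the result is likewise a limit. Among the compounds with values here, compound 3 is therefore the only compound here whose potency can be placed on the scale, and it is weak.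

Compound 4 is `Nc1ccc(Oc2ccccc2-c2ccc(S(=O)(=O)NCCNC(=O)Nc3cc(C(F)(F)F)cc(C(F)(F)F)c3)s2)cc1`. It differs from compound 3 in one place: 4-aminophenyl in place of benzyl on an oxygen on an aromatic ring. Within the data shown here, no measured pair here differs in just one place, so there is no step to lean on for the size of this change. The change swaps one aromatic ring for another of the same size, adding a single donor and acceptor at the far end. Without any measured guide, the expected step from compound 3 to compound 4 in this assay is a 1.2-fold lower number from compound 3 to compound 4 (0.09 log units; within the scatter), that is, no change beyond the usual scatter in either direction.

Compound 4 is therefore expected to give about 11000 nM in this assay, with a plausible range from 3000 nM to 40000 nM.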

Compound 4, half-maximal inhibitory concentration: > 20000 nM
Compound 4 was reported as a limit; the forecaster's own chance of this, stated with the estimate: 25%; middle value at least 1.8-fold (0.25 log units) away from the limit.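

In this assay compound 4 gives > 20000 nM, which is a limit of the assay and not a number. Within the data shown here, this is the first step in the set that compares two compounds differing in one place, and 4-aminophenyl in place of benzyl on an oxygen on an aromatic ring reads as an at least 1.4-fold higher number from compound 3 to compound 4 (0.17 log units; that floor lies within the scatter), so the swap gives no sign of a stronger inhibitor at this position. The size of the step can be given only as a floor, and how far compound 4 really lies from compound 3 stays unknown, because the reading ends at a limit shared with another compound: the limit of > 20000 nM in this assay, at which 2 of the 4 values shown sit.

What the compounds shown leave open is which part of the change matters, since the swap removes benzyl and brings in a ring carrying an amine in one move, and a plain phenyl on the same oxygen would separate those two parts. From the compounds shown here alone, it also remains open whether a smaller group such as methyl, or a benzyl carrying a carboxylic acid, would move the number at this position in either direction.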